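Swapping the aryl group of compound 3

The source may report more compounds than this note shows. Statements on the series, on what has been measured and on what is new or still open speak of the compounds shown alone.

In a functional assay on MDA-MB-231 cells (Homo sapiens) for antiproliferative activity, read by MTT assay, with a stated time of 48 h (on this read-out lower numbers stand for stronger inhibition and higher numbers for weaker inhibition), three compounds sharing one core have been measured. Compound 1 `C=CS(=O)(=O)N1CCN(c2ncnc3sc(-c4ccc(N5CCN(C)CC5)cc4)cc23)CC1` gives 7550 nM, compound 2 `CN1CCN(c2ccc(-c3cc4c(N5CCN(S(=O)(=O)C6CC6)CC5)ncnc4s3)cc2)CC1` gives 11500 nM, and compound 3 `CN1CCN(c2ccc(-c3cc4c(N5CCN(C(=O)Nc6ccc(Cl)cc6)CC5)ncnc4s3)cc2)CC1` gives 5440 nM. Two steps fix where the last of these stands: a 1.4-fold lower number from compound 1 to compound 3 (0.14 log units; within the scatter), and a 2.1-fold lower number from compound 2 to compound 3 (0.33 log units; beyond the scatter), which is modest. Compound 4 `CN1CCN(c2ccc(-c3cc4c(N5CCN(C(=O)Nc6cc(C(F)(F)F)ccc6F)CC5)ncnc4s3)cc2)CC1` departs from it in one place, with 2-fluoro-5-(trifluoromethyl)phenyl in place of 4-chlorophenyl on an amide-type nitrogen. For the measured compounds named here, no measured compound alters this aryl group, so the evidence is only indirect. Replacing the whole group on the ring nitrogen produced just those two small steps, and a 1.5-fold higher number from compound 1 to compound 2 (0.18 log units; within the scatter) also stayed small. A change confined to the aryl group is therefore expected to be of similar size or smaller, with only a weak lean in direction. The expected step is a 1.2-fold lower number from compound 3 to compound 4 (0.08 log units; within the scatter). For compound 4, the estimate is 4500 nM, with an expected range of 1800 nM to 11000 nM.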

Compound 4, half-maximal inhibitory concentration: 9090 nM
Compound 4: the middle estimate sits 2.0-fold (0.31 log units) below what was measured; low and high end bracket the measured number.
By their numbers in this assay, from the lowest: compounds 3, 1, 4 and 2 (each within the scatter of the next, the first and the last beyond it).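

In this assay the aryl group on the amide-type nitrogen is now varied directly, and exchanging 4-chlorophenyl for 2-fluoro-5-(trifluoromethyl)phenyl gives a 1.7-fold higher number from compound 3 to compound 4 (0.22 log units; within the scatter) for this one change. The entering group brings four fluorine atoms and loses the chlorine, yet the step cannot be told from repeat scatter, so this position accepts this particular exchange without a clear shift in the read-out. Nothing shown bears on why the number lands where it does.

From the compounds shown here alone, the fluorine and the trifluoromethyl group entered together, so their separate contributions remain open. Also open, going by these compounds, is how a phenyl ring carrying an amine or a carboxylic acid, or a simple alkyl chain in place of the aryl group, would read in this assay on this nitrogen.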